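A few compounds are considered here, and "the series" means these few. Any claim that something is new, unique, unknown or untested is made for them only; others in the source may bear on it.

In a functional assay on SF-539 cells (Homo sapiens) for inhibition, read by sulforhodamine B assay, with a stated time of 48 h (a lower number here means a stronger inhibitor of growth, a higher number a weaker inhibitor of growth), two compounds sharing one core have been measured. Compound 1, `COc1ccc(Sc2nc3cc(N)cc(N)c3nc2-c2ccccc2)cc1`, carries a (4-methoxyphenyl)sulfanyl group. In this assay compound 1 gives only a limit, < 100000 nM. Compound 2, `Nc1cc(N)c2nc(-c3ccccc3)c(Oc3ccc(F)cc3)nc2c1`, carries a 4-fluorophenoxy group in the same place. In this assay, within the data shown here, compound 2 gives 35500 nM, the only plain number among the two. The other value sits at the limit of < 100000 nM in this assay, at which 1 of the 2 values shown sits. The step that the limit leaves unreadable from compound 1 to compound 2 is therefore unreadable.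

Compound 3, `Nc1cc(N)c2nc(-c3ccccc3)c(Sc3ccc(F)cc3)nc2c1`, is not yet measured. It differs from compound 2 in one place: (4-fluorophenyl)sulfanyl in place of 4-fluorophenoxy on an aromatic carbon. Among the measured compounds shown here, no measured step bears directly on this change, as the one step known swaps the whole group and its size is hidden by the limit. With no readable guide, the expectation is that compound 3 stays close to compound 2. For compound 3 the expected step is no change at the digits printed from compound 2 to compound 3 (within the scatter), within the usual scatter. Compound 3 is thus estimated at 35500 nM, with a plausible span from 9000 nM to 120000 nM.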

Compound 3, concentration for total growth inhibition: 39800 nM
Compound 3: the middle estimate sits 1.1-fold (0.05 log units) below what was measured; low and high end bracket the measured number.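

In this assay, among these compounds, putting (4-fluorophenyl)sulfanyl in place of 4-fluorophenoxy gives a 1.1-fold higher number from compound 2 to compound 3 (0.05 log units; within the scatter), the first step that can be read. The two groups have the same count of heavy atoms and the same aromatic ring, and they differ only in whether oxygen or sulfur links that ring to the core, so at this position, next to the ring nitrogen and ortho to a phenyl group, this assay does not tell the two links apart. The steps that start at compound 1, including fluoro in place of methoxy on the outer ring, cannot be read, because compound 1 gives only a limit and not a number: the limit of < 100000 nM in this assay, at which 1 of the 3 values shown sits.

From the compounds shown here alone, it remains open whether any group at this position can shift the number beyond the scatter, for example an amine or a carboxylic acid on the same carbon, or a longer chain between that carbon and the aromatic ring. Going by these compounds, the role of the fluoro on the outer ring is also open, and a chloro there or an unsubstituted phenyl ring would address it.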